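Fluoro for methoxy on the shared core

The source may hold more compounds than are shown below. What is called first, only, known or untested is meant among the compounds shown, and "the series" means these compounds.

Measured so far in a functional assay on PC-3 cells (Homo sapiens) for inhibition, read by sulforhodamine B assay, with a stated time of 48 h; a lower number here means a stronger inhibitor of growth, a higher number a weaker inhibitor of growth:
compound 1 `CCOC(=O)C1=C(C)NC(=S)NC1c1ccc(OC)cc1`: 5.5 ug/mL
compound 2 `CCOC(=O)C1=C(C)NC(=S)NC1C1CCCCC1`: 0.46 ug/mL
compound 3 `CCOC(=O)C1=C(C)NC(=O)NC1C1CCCCC1`: a limit of the assay, > 250 ug/mL

Of the two numbers, compound 1 holds the highest; compound 2 sits at a lower number, and the gap between the two is beyond the scatter. For compound 3 only a limit is known: the limit of > 250 ug/mL in this assay, at which 1 of the 3 values shown sits, so the value says that growth inhibition was not reached within the tested range.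

Compound 4 `CCOC(=O)C1=C(C)NC(=S)NC1c1ccc(F)cc1` is the next one to be measured. It differs from compound 1 by fluoro in place of methoxy on an aromatic carbon. Within the data shown here, no measured pair in this set covers a swap of this kind on the aromatic ring, so the expectation rests on compound 1 alone. The step of a 1.1-fold lower number from compound 1 to compound 4 (0.04 log units; within the scatter) is expected to be small, in no clear direction, and within the scatter of this assay. Compound 4 is therefore estimated at 5 ug/mL, with a range from 1.5 ug/mL to 15 ug/mL.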

Compound 4, concentration for 50% growth inhibition: 1.7 ug/mL
Estimate against measurement, compound 4: 2.9-fold (0.47 log units) above; low and high end bracket the measured number.
By their numbers in this assay, from the lowest: compound 2; then compound 4; then compound 1. At a limit, above all of these: compound 3.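

In this assay, fluoro in place of methoxy on the aromatic carbon para to a large group gives a 3.2-fold lower number from compound 1 to compound 4 (0.51 log units; beyond the scatter). Among these compounds, this is the first readable step at this position, and it shows that the number responds to an exchange of substituent there, not only to the larger differences among the other compounds. Among the compounds shown here, nothing measured so far accounts for the size of this step.

From the compounds shown here alone, whether the step comes from the arrival of fluoro or the departure of methoxy stays open, and a chloro, a trifluoromethyl or a plain hydrogen at the same carbon would help to separate the two. A single pair also cannot say whether the step would carry over to other changes on the shared core.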